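The source may hold more compounds than are shown below. What is called first, only, known or untested is meant among the compounds shown, and "the series" means these compounds.

So far two compounds built on a shared core have been measured in a functional assay on HepG2 cells (Homo sapiens) for antiproliferative activity, read by MTT assay (a higher number here means a weaker inhibitor, a lower number a stronger inhibitor), and they lie far apart. Compound 1 (`Clc1ccc(Nc2nccc(-c3ccc(Br)cc3)n2)c(Cl)c1`) gives 720 nM there, while compound 2 (`O=[N+]([O-])c1ccc(Nc2nccc(-c3ccc(Br)cc3)n2)cc1`) gives 43000 nM and so holds the higher of the two numbers. It is the weaker inhibitor of the pair, by a gap well beyond the scatter.

For the measured compounds named here, the next compound to consider is compound 3 (`Clc1ccc(Nc2nccc(-c3ccc(Br)cc3)n2)cc1`), which has no measurement yet. It differs from compound 2 at one place (chloro in place of nitro on an aromatic carbon): chloro in place of nitro on an aromatic carbon, para to a large group.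

Going by the values given here, no measured pair shows this swap on its own, so its size can only be judged indirectly. Compound 1 also carries chloro and gives 720 nM in this assay which suggests that compound 3 will land well under compound 2 on the scale. A step of a 14-fold lower number from compound 2 to compound 3 (1.16 log units; beyond the scatter) is expected, downward and beyond the scatter. The estimated value for compound 3 is 3000 nM with 700 nM to 13000 nM as the expected range.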

Compound 3, half-maximal inhibitory concentration: 47500 nM
Compound 3: the middle estimate sits 16-fold (1.20 log units) below what was measured; measured number above the stated range.
By their numbers in this assay, from the lowest: compound 1; then compounds 2 and 3 (each within the scatter of the next).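

In this assay, putting chloro in place of nitro on this aromatic carbon, para to a large group, gives a 1.1-fold higher number from compound 2 to compound 3 (0.04 log units; within the scatter), so the two groups cannot be told apart at this position, although they differ in size and in hydrogen-bond acceptors. The large step lies elsewhere: a 66-fold higher number from compound 1 to compound 3 (1.82 log units; beyond the scatter), with hydrogen in place of chloro on an aromatic carbon, shows that the second chloro of compound 1, absent from compound 3, goes with much stronger inhibition, while a single chloro on this ring does not bring that strength on its own. No measurement is at hand that accounts for either step.

On these data alone, only nitro and chloro have been seen at the first position, so it remains open whether an amine, a methoxy group or a carboxylic acid there would also leave the number in the same range. As far as these compounds go, it is also open whether the second chloro keeps its large effect when the other chloro is replaced by hydrogen, or whether the two chloro groups are needed together.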